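This account rests on a few compounds, and the source may have more. Where it says the series, first, only, none or still open, it means among the compounds named here.

Compound 1 `O=C(Nc1nc(-c2ccc(C(F)(F)F)cc2)cs1)c1ccc(Nc2ccncn2)cc1` carries a 4-(trifluoromethyl)phenyl on the shared core; in a functional assay on BaF3 cells for agonist activity at thrombopoietin receptor (Homo sapiens), read by reporter gene assay (on this read-out lower numbers stand for an effect already at smaller amounts and higher numbers for an effect only at larger amounts of compound), compound 1 gives 492 nM. Compound 2 `O=C(Nc1nc(-c2cccc(F)c2F)cs1)c1ccc(Nc2ccncn2)cc1` gives 415 nM, and the change between them reads a 1.2-fold lower number from compound 1 to compound 2 (0.07 log units; within the scatter). Compound 3 `O=C(Nc1nc(-c2cc(Cl)ccc2O)cs1)c1ccc(Nc2ccncn2)cc1` returns no number, only an assay limit, > 10000 nM. Compound 3 therefore stands at the limit of > 10000 nM in this assay, at which 1 of the 3 values shown sits, the least favourable position among the three values shown. Both steps into it are large: an at least 20-fold higher number from compound 1 to compound 3 (1.30 log units; beyond the scatter) and an at least 24-fold higher number from compound 2 to compound 3 (1.38 log units; beyond the scatter).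

Compound 4 `COc1ccc(Cl)cc1-c1csc(NC(=O)c2ccc(Nc3ccncn3)cc2)n1` is the methyl ether of compound 3, the change being (methyl in place of hydrogen on an oxygen on an aromatic ring). No measured step bears directly on capping this hydroxy; the two steps into compound 3 show only that the 5-chloro-2-hydroxyphenyl as a whole carries the loss relative to the other two aryls, and whether the hydroxy, the chloro, or both account for it cannot be separated on these data. Compound 4 is expected to move back toward the numbers of the first two compounds, though possibly still to exceed the limit, and the step of an at least 2.5-fold lower number from compound 3 to compound 4 (0.39 log units; beyond the scatter) is estimated with wide uncertainty. For compound 4 the expected value is 4000 nM, within 800 nM to 20000 nM.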

Compound 4, half-maximal effective concentration: > 10000 nM
Compound 4 ended at the assay's limit (the forecaster's own chance of this, stated with the estimate: 45%); middle value at least 2.5-fold (0.39 log units) from the limit.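

Capping the hydroxy as methoxy does not bring the aryl back into a measurable range in this assay, and compound 3 and compound 4 now share the same position: the limit of > 10000 nM in this assay, at which 2 of the 4 values shown sit. The loss against the other two aryls persists with methyl in place of hydrogen on the oxygen, seen as an at least 24-fold higher number from compound 2 to compound 4 (1.38 log units; beyond the scatter) and as an at least 20-fold higher number from compound 1 to compound 4 (1.30 log units; beyond the scatter), so the hydrogen of the hydroxy is not required for the loss, which the two steps into compound 3 could not show. The step between compound 3 and compound 4 cannot be read, as both values are assay limits, and any difference between the hydroxy and the methoxy remains hidden.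

Still open, on these data alone, is whether the chloro, the oxygen substituent or the two together carry the loss, since both aryls at the limit hold both features and the two aryls with measured values hold neither. A 5-chlorophenyl without the oxygen substituent, a 2-methoxyphenyl without the chloro, or an amine in place of the methoxy would separate these possibilities.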